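The source may hold more compounds than are shown below. What is called first, only, known or untested is meant among the compounds shown, and "the series" means these compounds.

Compound 3 `CC(C)c1cccc(C(C)C)c1OS(=O)(=O)NC(=O)O[C@@H]1C[C@H](C)CCC1C(C)C` belongs to a small set of carbamates built on the same core. In an assay on liver for inhibition of sterol O-acyltransferase 1 (Rattus norvegicus), using microsomes (a lower number here means a stronger inhibitor, a higher number a weaker inhibitor), compound 3 gives 21000 nM, a number that sits between those of compound 1 `CC(C)c1cccc(C(C)C)c1NS(=O)(=O)NC(=O)Oc1c(C(C)(C)C)cccc1C(C)(C)C`, which gives 16800 nM, and compound 2 `CC(C)c1cccc(C(C)C)c1OS(=O)(=O)NC(=O)OC1CCCCC1`, which gives 38000 nM, with both gaps inside the usual scatter. For the measured compounds named here, the one measured step on the carbamate oxygen, a 1.8-fold lower number from compound 2 to compound 3 (0.26 log units; within the scatter), changed nothing beyond the scatter. Compound 4 `CC(C)c1cccc(C(C)C)c1OS(=O)(=O)NC(=O)Oc1c(F)cccc1F` differs from compound 3 by 2,6-difluorophenyl in place of 2-isopropyl-5-methylcyclohexyl on an oxygen next to a carbonyl group. Going by the values given here, no measured step places an aromatic ring at this position within the sulfamate core, so the expectation rests on the flatness seen so far: a step of about a 1.1-fold lower number from compound 3 to compound 4 (0.02 log units; within the scatter) is expected. Compound 4 is therefore estimated at 20000 nM, with a likely range from 7000 nM to 60000 nM.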

Compound 4, half-maximal inhibitory concentration: 65000 nM
Compound 4: the middle estimate sits 3.3-fold (0.51 log units) below what was measured, and the stated range ends below it.
By their numbers in this assay, from the lowest: compounds 1, 3, 2 and 4 (each within the scatter of the next, the first and the last beyond it).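

In this assay, for the compounds shown here, the group on this oxygen turned out to matter: 2,6-difluorophenyl in place of 2-isopropyl-5-methylcyclohexyl gave a 3.1-fold higher number from compound 3 to compound 4 (0.49 log units; beyond the scatter) and is the only step here beyond the scatter. The same group in place of cyclohexyl gave a 1.7-fold higher number from compound 2 to compound 4 (0.23 log units; within the scatter) and stays within the scatter, so the effect appears against one saturated ring only. The compounds shown leave open whether the ring or its fluorine atoms carry this step, which an unsubstituted phenyl would help separate. Nothing available bears on the reason for the result.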